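A few compounds are considered here, and "the series" means these few. Any claim that something is new, unique, unknown or untested is made for them only; others in the source may bear on it.

Compound 2 `O=C(O)c1ccccc1-c1ccc(CCc2ncc(Cc3ccccc3F)[nH]2)cc1` has the lowest number of the two measured in an in vitro functional assay on cells for agonist activity at Bombesin receptor subtype-3 (Homo sapiens), read by luminescence and calcium flux (a lower number here means that less compound is needed, a higher number that more compound is needed for the effect), where compound 2 gives 177 nM. Compound 1 `CCCCc1cnc(C(C)Cc2ccc(-c3ccccc3C(=O)O)cc2)[nH]1` gives 2760 nM in this assay, a higher number than compound 2 and beyond the scatter. Compound 3 `CC(C)(C)CCc1cnc(CCc2ccc(-c3ccccc3C(=O)O)cc2)[nH]1` has not been measured; it differs from compound 2 as neopentyl in place of 2-fluorophenyl on a saturated chain carbon bound to an aromatic carbon. With no comparable change among the measured pairs, the step from compound 2 to compound 3 is expected to run toward a higher number, estimated at a 4.5-fold higher number from compound 2 to compound 3 (0.66 log units; beyond the scatter). Compound 3 is accordingly expected to give an estimated 800 nM in this assay, within a range from 250 nM to 3000 nM.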

Compound 3, half-maximal effective concentration: 39 nM
Compound 3: the middle estimate sits 21-fold (1.31 log units) above what was measured, outside the stated range (below it).
By their numbers in this assay, from the lowest: compound 3; then compound 2; then compound 1.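

In this assay, the change from 2-fluorophenyl to neopentyl on a saturated chain carbon bound to an aromatic carbon gives a 4.5-fold lower number from compound 2 to compound 3 (0.66 log units; beyond the scatter). This position therefore does not depend on an aromatic ring, and a branched all-carbon group without a ring serves better here than the 2-fluorobenzyl arrangement. Nothing available explains this gain.

Going by these compounds, it remains open how an unbranched hexyl chain, a cyclohexyl ring or an amine would fare at this position. This single step also leaves open whether the fluorine contributes anything to the value of compound 2.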